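Swapping Chloro for Fluoro on the Sulfonyl Ring

The source may hold more compounds than are shown below. What is called first, only, known or untested is meant among the compounds shown, and "the series" means these compounds.

Of the compounds shown here, three that share one core have been tested in an assay on isolated protein for displacement of a labelled ligand from metabotropic glutamate receptor 5 (Homo sapiens), with a stated time of 60 min, tested at 1 uM; on this read-out lower numbers stand for less inhibition and higher numbers for more inhibition at the one concentration tested (going by the name of the read-out). Compound 1 `Cc1ccc(S(=O)(=O)c2cnc3cc(F)ccc3c2N2CCC(C)CC2)cc1C` gives 90%. In this assay compound 2 `COc1ccc(S(=O)(=O)c2cnc3cc(F)ccc3c2N2CCC(C)CC2)cc1OC` gives 83%. In this assay compound 3 `CC1CCN(c2c(S(=O)(=O)c3ccc(Cl)cc3)cnc3cc(F)ccc23)CC1` gives 90%. On these numbers compound 3 stands level with compound 1, the two together at the top of the three, with compound 1 its nearest neighbour and compound 2 its furthest.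

All three measured steps sit on the ring carried by the sulfonyl sulfur: a number 7 percentage points lower from compound 1 to compound 2 (within the scatter), no change at the digits printed from compound 1 to compound 3 (within the scatter) and a number 7 percentage points higher from compound 2 to compound 3 (within the scatter). Each lies within the scatter.

Compound 4 `CC1CCN(c2c(S(=O)(=O)c3ccc(F)cc3)cnc3cc(F)ccc23)CC1` differs from compound 3 only in fluoro in place of chloro on an aromatic carbon. Among the measured compounds shown here, no measured step exchanges one halogen for another, so the closest guide is that every change tried so far on this ring, including the move from 3,4-dimethylphenyl to 4-chlorophenyl, no change at the digits printed from compound 1 to compound 3 (within the scatter), shifted the read-out by nothing beyond the scatter. Only a small step is therefore expected: a number 3 percentage points lower from compound 3 to compound 4 (within the scatter). Compound 4 is estimated to give 87%, with a likely range from 74% to 96%.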

Compound 4, a percentage reported as inhibition, at one concentration (the size of the read-out at that concentration, not a potency): 74.5%
Beside the measured number, compound 4's estimate is 12.5 percentage points above it; the measured number falls inside the stated range.
By their numbers in this assay, from the lowest: compounds 4, 2, 1 and 3 (each within the scatter of the next, the first and the last beyond it).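

In this assay, among the compounds shown here, exchanging chloro for fluoro on the ring carried by the sulfonyl sulfur gives a number 15.5 percentage points lower from compound 3 to compound 4 (beyond the scatter), the first step on this ring to reach beyond the scatter, so this position is less indifferent to change than the first three compounds suggested. The 4-fluorophenyl group also separates from the 3,4-dimethylphenyl group, with a number 15.5 percentage points lower from compound 1 to compound 4 (beyond the scatter), whereas the step from the 3,4-dimethoxyphenyl group is a number 8.5 percentage points lower from compound 2 to compound 4 (within the scatter), so these two aryl groups cannot be told apart on this read-out. Nothing available here says why a change of a single halogen atom on this ring registers in this way.

A bromo group or a nitrile in the same place would help show whether chloro and fluoro are two points on a wider trend or whether fluoro alone stands apart on this ring. On these data alone, it also remains open whether the same exchange would give a similar step with another group on the shared core, and whether full concentration-response measurements would preserve the separation seen at this one test concentration.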